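The compounds below may be only part of what the source reports. "The series", "measured", "known", "first", "only" and "open" are said of these compounds alone.

Measured in an ADME assay on MDBK cells (Bos taurus) for cytotoxicity; a higher number here means that more compound is tolerated, a lower number that less compound is tolerated:

Compound 1 `Cc1cccc(Cn2ccc3nc(-c4ccccc4)nc-3c2)c1`: > 100000 nM (a limit)
Compound 2 `Cc1ccc(Cn2ccc3nc(-c4ccccc4)nc-3c2)cc1`: > 100000 nM (a limit)
Compound 3 `Fc1ccccc1Cn1ccc2nc(-c3ccccc3)nc-2c1`: > 100000 nM (a limit)

Compound 3 has no numerical value in this assay, only the limit > 100000 nM. The whole measured set stands at the limit of > 100000 nM in this assay, at which 3 of the 3 values shown sit. Compound 4 `Fc1ccc(Cn2ccc3nc(-c4ccccc4)nc-3c2)cc1` differs from compound 3 by 4-fluorophenyl in place of 2-fluorophenyl on a saturated chain carbon bound to an aromatic nitrogen, with 4-fluorophenyl in place of 2-fluorophenyl on a saturated chain carbon bound to an aromatic nitrogen.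

Among the compounds with values here, all the measured steps bear on this change, as each swaps one group at that same place. They are a step that the two limits leave unreadable from compound 1 to compound 2, a step that the two limits leave unreadable from compound 1 to compound 3 and a step that the two limits leave unreadable from compound 2 to compound 3. None of them therefore has a size that can be read, but no change at this place has brought a compound off the limit. On the strength of the limit of > 100000 nM in this assay, at which 3 of the 3 values shown sit, no step beyond the usual scatter is expected in this assay, and no direction is expected either. The expected step is a number no higher from compound 3 to compound 4 (the limit leaves the size open). For compound 4 the estimated value is 100000 nM, most likely reported again only as a limit. The expected range for compound 4 runs from 50000 nM to 200000 nM.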

Compound 4, half-maximal cytotoxic concentration: > 100000 nM
Compound 4: a limit, no number (the forecaster's own chance of this, stated with the estimate: 85%); the middle value sits exactly at the limit.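

Within the data shown here, compound 4 gives only a limit in this assay, > 100000 nM, so no new step to compound 1, compound 2 or compound 3 can be read. The compounds shown leave open how much of each is actually tolerated, and whether any group at this place would bring a compound off the limit.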